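Fluoro to methyl on the aromatic ring of compound 2

This account rests on a few compounds, and the source may have more. Where it says the series, first, only, none or still open, it means among the compounds named here.

Measured compounds:
compound 1, `CCOC(=O)N1CCC(=NNC(=O)c2ccc(Cl)cc2)CC1`, 63900 nM
compound 2, `CCOC(=O)N1CCC(=NNC(=O)c2ccc(F)cc2)CC1`, 39200 nM

Compound 1 `CCOC(=O)N1CCC(=NNC(=O)c2ccc(Cl)cc2)CC1` and compound 2 `CCOC(=O)N1CCC(=NNC(=O)c2ccc(F)cc2)CC1` share one core and differ only in the group on the aromatic carbon. In a functional assay, read by spectrophotometry (on this read-out higher numbers stand for weaker inhibition and lower numbers for stronger inhibition), compound 1 gives 63900 nM, and in this assay compound 2 gives 39200 nM. For the measured compounds named here, the only measured step, a 1.6-fold lower number from compound 1 to compound 2 (0.21 log units; within the scatter), lies within the scatter, so compound 2 and compound 1 cannot be told apart on these numbers; compound 2 simply has the lower of the two figures, and that gap carries no weight.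

Compound 3 `CCOC(=O)N1CCC(=NNC(=O)c2ccc(C)cc2)CC1` is not yet measured. It differs from compound 2 by methyl in place of fluoro on an aromatic carbon. Going by the values given here, the one step that bears on it, a 1.6-fold lower number from compound 1 to compound 2 (0.21 log units; within the scatter), shows that exchanging one small group for another at this position left this assay essentially unchanged. Among the compounds with values here, nothing here points to a larger shift for a methyl at the same place, though no step with a methyl has been measured, so the expectation rests on a single comparison. Compound 3 is therefore expected to show a step of a 1.1-fold higher number from compound 2 to compound 3 (0.06 log units; within the scatter) relative to compound 2, that is, no change beyond the scatter. Compound 3 is estimated to give 45000 nM in this assay, within a range of 15000 nM to 130000 nM.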

Compound 3, half-maximal inhibitory concentration: 28100 nM
For compound 3 the middle estimate is 1.6-fold (0.20 log units) above the measured one; the measured number falls inside the stated range.
By their numbers in this assay, from the lowest: compounds 3, 2 and 1 (each within the scatter of the next, the first and the last beyond it).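

In this assay the exchange of fluoro for methyl on the aromatic carbon para to a large group gives a 1.4-fold lower number from compound 2 to compound 3 (0.14 log units; within the scatter) and so does not separate 4-fluorophenyl from 4-methylphenyl. For the compounds shown here, the new information lies in the comparison with the chloro compound, a 2.3-fold lower number from compound 1 to compound 3 (0.36 log units; beyond the scatter) and thus the first measured difference at this position to pass beyond the scatter, although it is only modest; fluoro stands apart from neither chloro nor methyl, so chloro and methyl are the only pair of these three groups that can be told apart. The material at hand offers no measurement that would explain this separation.

The compounds shown leave open whether any group at this position could move the number much further, since the three compared are all small and an amine, a carboxylic acid or a longer chain such as butyl is not among them. As far as these compounds go, it also remains open whether the same narrow spread would hold on a changed core, for instance with a benzyl group in place of the ethyl group of the carbamate.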